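Hydrazone series: hydrogen in place of fluoro

A few compounds are considered here, and "the series" means these few. Any claim that something is new, unique, unknown or untested is made for them only; others in the source may bear on it.

Two compounds of this series have been run in a functional assay (Mus musculus, strain BALB/C) for inhibition, read by MTT assay, with stated times of 24 h and 72 h; a higher number here means a weaker inhibitor, a lower number a stronger inhibitor. Compound 1 `COc1ccc(/C=N/NC(=O)c2ccc(C)cc2O)cc1` returned no number: in this assay compound 1 gives > 100000 nM, which is a limit of the assay. For the measured compounds named here, compound 2 `Cc1ccc(C(=O)N/N=C/c2ccccc2F)c(O)c1` holds the only measured number in the set; in this assay compound 2 gives 42100 nM. It therefore stands as the sole numeric point, the other value being a limit (the limit of > 100000 nM in this assay, at which 1 of the 2 values shown sits).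

Compound 3 `Cc1ccc(C(=O)N/N=C/c2ccccc2)c(O)c1` is still to be measured. It differs from compound 2 by hydrogen in place of fluoro on an aromatic carbon. Going by the values given here, no step between measured compounds is available, so the size of such a change cannot be read from the series itself. The step from compound 2 to compound 3 is expected to be a 1.3-fold higher number from compound 2 to compound 3 (0.12 log units; within the scatter), not beyond the usual scatter. For compound 3 in this assay the estimated value is 55000 nM, with a range of 20000 nM to 150000 nM. Since compound 1 sits at the limit (the limit of > 100000 nM in this assay, at which 1 of the 2 values shown sits), a limit read for compound 3 remains possible.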

Compound 3, half-maximal inhibitory concentration: 53900 nM
Compound 3: the middle estimate sits 1.0-fold (0.01 log units) above what was measured; the range from low to high includes it.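

On an aromatic carbon ortho to a large group, hydrogen in place of fluoro now has a measured size in this assay: the change gives a 1.3-fold higher number from compound 2 to compound 3 (0.11 log units; within the scatter), so compound 2 and compound 3 cannot be told apart in this read-out. Hydrogen in place of methoxy on an aromatic carbon gives an at least 1.8-fold lower number from compound 1 to compound 3 (0.26 log units; that floor lies within the scatter), which is a floor and not a full size for that change. The value of compound 1 is a limit of the assay and not a number: the limit of > 100000 nM in this assay, at which 1 of the 3 values shown sits.

The compounds shown leave open whether any replacement of the fluoro moves the number beyond the scatter, as fluoro and hydrogen alone cannot tell. An amine or a carboxylic acid on that aromatic carbon would be the next comparison to read against compound 3.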